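Working notes on the shared core: compound 2 to compound 3

The source may hold more compounds than are shown below. What is called first, only, known or untested is meant among the compounds shown, and "the series" means these compounds.

Compound 1 `C[C@@H]1CN(c2cccc3c2C[C@H](CN(C)[C@H]2CCCc4cccnc42)NC3)C[C@H](C)N1C` and compound 2 `CN1CCN(c2cccc3c2C[C@H](CN(C)[C@H]2CCCc4cccnc42)NC3)CC1` share a core and differ only in the group on an aromatic carbon. In a functional assay on CCRF-CEM cells for agonist activity at C-X-C chemokine receptor type 4 (Homo sapiens), read by calcium flux, with a stated time of 25 min (a lower number here means that less compound is needed, a higher number that more compound is needed for the effect), compound 1 gives > 30000 nM, which is a limit of the assay. In this assay compound 2 gives > 30000 nM, likewise a limit. The step that the two limits leave unreadable from compound 1 to compound 2 is thus unreadable, since (the limit of > 30000 nM in this assay, at which 2 of the 2 values shown sit). Compound 3 `CN(C[C@H]1Cc2c(cccc2N2CCN3CCC[C@H]3C2)CN1)[C@H]1CCCc2cccnc21` carries a group of 9 heavy atoms (7 carbon, 2 nitrogen; one five-membered non-aromatic ring with 1 hetero atom, one six-membered non-aromatic ring with 2 hetero atoms) in place of a group of 7 heavy atoms (5 carbon, 2 nitrogen; one six-membered non-aromatic ring with 2 hetero atoms), on an aromatic carbon. No readable measured step bears on this change. Compound 3 is therefore expected to give 40000 nM, within 10000 nM to 200000 nM. The implied step that the limit leaves unreadable from compound 2 to compound 3 is an estimate only.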

Compound 3, half-maximal effective concentration: > 30000 nM
Compound 3: only a limit was reported; the forecaster's own chance of this, stated with the estimate: 85%; the middle value lies beyond the limit too.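

No new step can be read among compound 1, compound 2 and compound 3, as all three results are limits of the assay: the limit of > 30000 nM in this assay, at which 3 of the 3 values shown sit.

The compounds shown leave open whether any group on this aromatic carbon gives a measurable value.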